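Larger groups on the aromatic nitrogen of the shared core

This account rests on a few compounds, and the source may have more. Where it says the series, first, only, none or still open, it means among the compounds named here.

Measured compounds:
compound 1 `C/C(=C\C(=O)Nc1ccccc1OCCCC(=O)O)c1ccc2c(ccn2CC(C)C)c1`: 160 nM
compound 2 `CCCC(C)n1ccc2cc(/C(C)=C/C(=O)Nc3ccccc3OCCCC(=O)O)ccc21`: 7.8 nM
compound 3 `C/C(=C\C(=O)Nc1ccccc1OCCCC(=O)O)c1ccc2c(ccn2C(C(C)C)C(C)C)c1`: 14 nM

In an assay on Prostate gland for inhibition of steroid 5-alpha-reductase (Rattus norvegicus) (on this read-out lower numbers stand for stronger inhibition and higher numbers for weaker inhibition), compound 1 gives 160 nM, the highest of the three numbers, meaning the weakest inhibition of the set. Compound 2 gives 7.8 nM and compound 3 gives 14 nM; the gap between them, a 1.8-fold higher number from compound 2 to compound 3 (0.25 log units; within the scatter), is within the scatter, so the two cannot be ordered.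

Compound 4 `CCCCC(c1ccccc1)n1ccc2cc(/C(C)=C/C(=O)Nc3ccccc3OCCCC(=O)O)ccc21` has not been measured in this assay. It differs from compound 1 in one place: 1-phenylpentyl in place of isobutyl on an aromatic nitrogen. Both measured steps from compound 1 enlarge the group on the aromatic nitrogen of the shared core and both lower the number by a large margin: a 21-fold lower number from compound 1 to compound 2 (1.31 log units; beyond the scatter) and an 11-fold lower number from compound 1 to compound 3 (1.06 log units; beyond the scatter). The change to compound 4 also enlarges that group, and the enlargement is still bigger than in compound 2 or compound 3, adding a six-membered aromatic ring. Among the measured compounds shown here, no measured compound shows how such a ring at this place behaves, so the direction is taken from the two measured steps while the size is held close to them.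

Compound 4 is therefore expected to give 12 nM, in the range 3 nM to 50 nM, an estimated step of a 13-fold lower number from compound 1 to compound 4 (1.12 log units; beyond the scatter).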

Compound 4, half-maximal inhibitory concentration: 9.8 nM
Compound 4: middle estimate off by 1.2-fold (0.09 log units), on the high side; the measured number falls inside the stated range.
By their numbers in this assay, from the lowest: compounds 2, 4 and 3 (each within the scatter of the next); then compound 1.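

In this assay the group on the aromatic nitrogen can carry a six-membered aromatic ring of carbon only: with 1-phenylpentyl, 11 heavy atoms against 4 for isobutyl, the result is a 16-fold lower number from compound 1 to compound 4 (1.21 log units; beyond the scatter) and so the large drop seen with the earlier groups is kept. Set against the other two larger groups, the result is a 1.4-fold lower number from compound 3 to compound 4 (0.15 log units; within the scatter) and also a 1.3-fold higher number from compound 2 to compound 4 (0.10 log units; within the scatter) so that compounds 2, 3 and 4 cannot be ordered, and the added ring brings no step beyond the scatter. Compounds 2, 3 and 4 also share a feature that compound 1 lacks, a branch on the chain carbon bound to the aromatic nitrogen, so among these four compounds the effect of group size cannot be separated from the effect of that branch.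

As far as these compounds go, a plain benzyl group would separate the ring from the pentyl chain, and a chain ending in an amine or a carboxylic acid would show how this position responds to something other than carbon, but how either would read remains open. Why these three different groups end up so close also stays open, as no supporting evidence bears on this result.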